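Replacing Phenethyl with 3-Methoxyphenyl on a Carbonyl Carbon

A few compounds are considered here, and "the series" means these few. Any claim that something is new, unique, unknown or untested is made for them only; others in the source may bear on it.

In a functional assay on HCT-116 cells (Homo sapiens) for antiproliferative activity, read by MTT assay, with a stated time of 72 h (on this read-out higher numbers stand for weaker inhibition and lower numbers for stronger inhibition), compound 1 `CCC(=O)N(C)c1ccc2[nH]c(-c3n[nH]c4ccccc34)cc2n1` gives 10800 nM, and compound 2 `CN(C(=O)CCc1ccccc1)c1ccc2[nH]c(-c3n[nH]c4ccccc34)cc2n1` gives 11200 nM. Among the measured compounds shown here, these two values lie within the scatter of each other, so compound 2 stands level with its only measured neighbour. For the measured compounds named here, the one measured step is a 1.0-fold higher number from compound 1 to compound 2 (0.02 log units; within the scatter), made with phenyl in place of hydrogen on a saturated chain carbon. Compound 3 `COc1cccc(C(=O)N(C)c2ccc3[nH]c(-c4n[nH]c5ccccc45)cc3n2)c1` keeps the shared core but carries 3-methoxyphenyl in place of phenethyl on a carbonyl carbon. Going by the values given here, the measured step is the only guide, and it says nothing directly about the entering group, so the forecast is uncertain. Among the compounds with values here, with only that small step to go on, no move beyond the scatter is expected in this assay, and the expected step is a 1.2-fold lower number from compound 2 to compound 3 (0.09 log units; within the scatter). For compound 3 the estimate is 9000 nM, with an expected range of 3000 nM to 27000 nM.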

Compound 3, half-maximal inhibitory concentration: 14200 nM
The estimate for compound 3 lay 1.6-fold (0.20 log units) below the measured number; low and high end bracket the measured number.
By their numbers in this assay, from the lowest: compounds 1, 2 and 3 (each within the scatter of the next).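

Putting 3-methoxyphenyl in place of phenethyl on a carbonyl carbon gives a 1.3-fold higher number from compound 2 to compound 3 (0.10 log units; within the scatter) in this assay and putting it in place of ethyl gives a 1.3-fold higher number from compound 1 to compound 3 (0.12 log units; within the scatter) on the same read-out. The earlier pair covered only ethyl and phenethyl, whereas this position now also carries an aromatic ring bonded straight to the carbonyl carbon, with a hydrogen-bond acceptor in the entering group, and all three compounds still read level. No supporting information bears on why these groups read alike.

The compounds shown leave open whether any group on this carbonyl carbon can produce a step beyond the scatter. A longer chain ending in an amine or a carboxylic acid could test that, and the part played by the methoxy group of 3-methoxyphenyl also remains unsettled.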